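The source may hold more compounds than are shown below. What is called first, only, known or untested is meant among the compounds shown, and "the series" means these compounds.

Working notes on the series. In a functional assay on cells (Cancer cell lines, Homo sapiens) for inhibition (a higher number here means a weaker inhibitor of growth, a lower number a stronger inhibitor of growth), compound 1 `O=Cc1c(-c2ccc([N+](=O)[O-])cc2)nc2sc(Cc3ccccc3)nn12` gives 26900 nM, the lowest of the three numbers measured; compound 2 `O=[N+]([O-])c1ccc(-c2nc3sc(Cc4ccccc4)nn3c2Br)cc1` gives 47900 nM and compound 3 `O=Cc1c(-c2ccc(F)cc2)nc2sc(CCC3CCCCC3)nn12` gives 67600 nM. Among the measured compounds shown here, the only single-point step measured so far, a 1.8-fold higher number from compound 1 to compound 2 (0.25 log units; within the scatter), is a bromo in place of formyl on an aromatic carbon and stays within the scatter. Compound 4 `O=Cc1c(-c2ccc(Br)cc2)nc2sc(Cc3ccccc3)nn12` differs from compound 1 by bromo in place of nitro on an aromatic carbon. For the measured compounds named here, no measured step bears directly on an exchange of nitro for bromo; the one step with a bromo entering was small, so the step is expected to be a 1.1-fold higher number from compound 1 to compound 4 (0.05 log units; within the scatter), not beyond the scatter in either direction. Compound 4 is therefore estimated at 30000 nM, within 10000 nM to 90000 nM.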

Compound 4, concentration for total growth inhibition: 7400 nM
For compound 4 the middle estimate is 4.1-fold (0.61 log units) above the measured one; the whole stated range lies above it.
By their numbers in this assay, from the lowest: compound 4; then compounds 1, 2 and 3 (each within the scatter of the next, the first and the last beyond it).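

In this assay, among the compounds shown here, the aromatic carbon para to a large group is the first place where a single change moves the number beyond the scatter: bromo in place of nitro gives a 3.6-fold lower number from compound 1 to compound 4 (0.56 log units; beyond the scatter). The change of formyl to bromo, by contrast, stays within the scatter. Nothing available explains the effect of this exchange.

Going by these compounds, it remains open whether a lower number is particular to bromo at this place or also follows with chloro or an amine. Also open, on these data alone, is whether the same exchange would lower the number for compound 2, which carries bromo in place of formyl.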